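The compounds below may be only part of what the source reports. "The series", "measured", "known", "first", "only" and "open" are said of these compounds alone.

Measured compounds in the series:

compound 1 `ClCc1ccccc1Cn1cnc2c(Cl)nc(Cl)nc21` — 360 nM
compound 2 `ClCc1ccccc1Cn1cnc2c(Cl)ncnc21` — 5240 nM
compound 3 `ClCc1cccc(Cn2cnc3ncnc(Cl)c32)c1` — 14100 nM

In a functional assay on LOX IMVI cells (Homo sapiens) for cytotoxicity, read by sulforhodamine B assay, with a stated time of 48 h (a higher number here means a weaker inhibitor of growth, a lower number a stronger inhibitor of growth), compound 2 stands second highest of the three numbers, nearest to compound 3 and furthest from compound 1. Going by the values given here, the one step that touches the same position is a 15-fold higher number from compound 1 to compound 2 (1.16 log units; beyond the scatter), so this carbon of the shared core, which sits between two ring nitrogen atoms, meta to a chloro group, meta to a fused ring and para to a fused ring, is a sensitive place.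

Compound 4 `Nc1nc(Cl)c2ncn(Cc3ccccc3CCl)c2n1` has not yet been measured. It differs from compound 2 by amino in place of hydrogen on an aromatic carbon. Among the compounds with values here, no measured step puts an amino group at this position; the only bearing step is that from compound 1 to compound 2, which shows the site matters but not what an amino group does there. The direction is therefore open, and the expected step is a 1.3-fold lower number from compound 2 to compound 4 (0.12 log units; within the scatter), kept small. Compound 4 is estimated at 4000 nM, in a range from 800 nM to 20000 nM.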

Compound 4, concentration for total growth inhibition: 21900 nM
For compound 4 the middle estimate is 5.5-fold (0.74 log units) below the measured one, and the stated range ends below it.
By their numbers in this assay, from the lowest: compound 1; then compound 2; then compounds 3 and 4 (each within the scatter of the next).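

In this assay, amino in place of hydrogen on this carbon between two ring nitrogen atoms gives a 4.2-fold higher number from compound 2 to compound 4 (0.62 log units; beyond the scatter), so the site responds in both directions from hydrogen: chloro gave the lower number, amino gives the higher one. Amino in place of chloro gives a 61-fold higher number from compound 1 to compound 4 (1.78 log units; beyond the scatter), the widest step at this position among the compounds shown, so the identity of the group here, and not only the presence of a heavy atom, sets the number. No supporting data accompany these steps, so the reason for this order remains unexplained.

The compounds shown leave open where groups such as bromo, methoxy or dimethylamino would fall at this carbon relative to chloro and amino. They also leave open whether the same order holds with the chloromethyl group in its position in compound 3.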